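From 2-chlorophenyl to 4-methylphenyl on the shared core

A few compounds are considered here, and "the series" means these few. Any claim that something is new, unique, unknown or untested is made for them only; others in the source may bear on it.

In a functional assay on BGC-823 cells (Homo sapiens) for antiproliferative activity, read by MTT assay, with a stated time of 24 h (a lower number here means a stronger inhibitor, a higher number a weaker inhibitor), compound 1 (`c1ccc(CSc2nnc(-c3ccc4c(c3)OCCO4)n2-c2ccccc2)cc1`) gives 73400 nM, while compound 2 (`Clc1ccccc1CSc1nnc(-c2ccc3c(c2)OCCO3)n1-c1ccccc1`) gives 17400 nM, the lower of the two numbers. Compound 3 (`Cc1ccc(CSc2nnc(-c3ccc4c(c3)OCCO4)n2-c2ccccc2)cc1`) has 4-methylphenyl in place of 2-chlorophenyl on a saturated chain carbon bound to a sulfur. Among the compounds with values here, the one measured step that bears on this is a 4.2-fold lower number from compound 1 to compound 2 (0.63 log units; beyond the scatter), for chloro in place of hydrogen on an aromatic carbon. Within the data shown here, compound 3 has no chloro, so part of that step should be lost, though no measured step covers the methyl. The expected change in this assay is a modest rise, a 2.2-fold higher number from compound 2 to compound 3 (0.34 log units; beyond the scatter). For compound 3 the estimate is 38000 nM, with an expected range of 14000 nM to 95000 nM.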

Compound 3, half-maximal inhibitory concentration: 44300 nM
The estimate for compound 3 lay 1.2-fold (0.07 log units) below the measured number; measured number inside the range.
By their numbers in this assay, from the lowest: compound 2; then compounds 3 and 1 (each within the scatter of the next).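

In this assay the change from 2-chlorophenyl to 4-methylphenyl on a saturated chain carbon bound to a sulfur gives a 2.5-fold higher number from compound 2 to compound 3 (0.41 log units; beyond the scatter) and so does not keep the standing of compound 2. Adding the methyl alone, a change the earlier compounds did not cover, gives a 1.7-fold lower number from compound 1 to compound 3 (0.22 log units; within the scatter) and so does not set compound 3 apart from compound 1. No evidence here accounts for these results.

The compounds shown leave open whether 4-chlorophenyl or 2-methylphenyl would read like compound 2 or like compound 3, so group and ring position remain unseparated. Going by these compounds, how an amine or a methoxy group on that ring would read also stays open.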